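Urea to Amide on a Shared Core

A few compounds are considered here, and "the series" means these few. Any claim that something is new, unique, unknown or untested is made for them only; others in the source may bear on it.

Compound 2 `COc1cc(Cl)cc(-c2nn(-c3cccc(NC(=O)Nc4ccc(Cl)c(C(F)(F)F)c4)c3)cc2-c2ccncc2)c1` is tested in a functional assay on NCI-H226 cells (Homo sapiens) for inhibition, read by sulforhodamine B assay, with a stated time of 48 h, tested at 0.01 uM (on this read-out lower numbers stand for a stronger effect and higher numbers for a weaker effect at the one concentration tested), where compound 2 gives 97%. Compound 1 `O=C(Nc1cccc(-n2cc(-c3ccncc3)c(-c3cc(O)cc(Cl)c3)n2)c1)Nc1ccc(Cl)c(C(F)(F)F)c1` gives 97%, and compound 3 `COc1cc(Cl)cc(-c2nn(-c3cccc(NC(=O)Nc4cc(C(F)(F)F)cc(C(F)(F)F)c4)c3)cc2-c2ccncc2)c1` gives 101%; compound 2 stands level with compound 1, and all three values lie within the scatter of each other. Among the measured compounds shown here, the only measured step, a methyl in place of hydrogen on an oxygen on an aromatic ring, shows no change at the digits printed from compound 1 to compound 2 (within the scatter). Compound 4 `COc1cc(Cl)cc(-c2nn(-c3cccc(NC(=O)c4cccc(C(F)(F)F)c4)c3)cc2-c2ccncc2)c1` differs from compound 2 by 3-(trifluoromethyl)phenyl in place of (4-chloro-3-(trifluoromethyl)phenyl)amino on a carbonyl carbon. For the measured compounds named here, no measured step touches this carbonyl carbon, and every measured value sits near the top of the scale, so the expected step is a number 2 percentage points higher from compound 2 to compound 4 (within the scatter), none beyond the scatter. Compound 4 is therefore estimated at 99%, with a range from 88% to 110%.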

Compound 4, a percentage reported as activity, at one concentration (the size of the read-out at that concentration, not a potency): 95%
Compound 4: middle estimate off by 4 percentage points, on the high side; measured number inside the range.
By their numbers in this assay, from the lowest: compounds 4, 1, 2 and 3 (each within the scatter of the next).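

Swapping the (4-chloro-3-(trifluoromethyl)phenyl)amino on the carbonyl carbon for 3-(trifluoromethyl)phenyl turns the urea into an amide and gives a number 2 percentage points lower from compound 2 to compound 4 (within the scatter) in this assay. Among the compounds shown here, this is the first change at this position, and neither the amino nitrogen nor the chlorine shows a readable effect at this single low concentration. No evidence on the cause of this result is at hand. Still open, as far as these compounds go, is whether an amine or a carboxylic acid on this ring would lower the number, and whether compound 2 and compound 4 would separate at a higher concentration.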